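A few compounds are considered here, and "the series" means these few. Any claim that something is new, unique, unknown or untested is made for them only; others in the source may bear on it.

Measured so far in an assay on isolated protein for binding affinity to Sigma non-opioid intracellular receptor 1 (Homo sapiens), read by radioligand binding; a lower number here means a stronger inhibitor, a higher number a weaker inhibitor:

compound 1, `CN1CCN(CCCCc2ccccc2)CC1` — 20 nM
compound 2, `CC1CCN(CCCCC(c2ccccc2)c2ccccc2)CC1` — 0.09 nM

Compound 2 holds the lowest of the two numbers in this assay; its nearest neighbour is compound 1, whose figure lies well beyond the scatter of the pair. Compound 1 and compound 2 differ in more than one place, so their two values are noted side by side and not read as a single step.

Compound 3, `CCN(CC)CCCCC(c1ccccc1)c1ccccc1`, has not yet been measured in this assay. It differs from compound 2 in one place: diethylamino in place of 4-methylpiperidin-1-yl on a saturated chain carbon, five bonds along the chain from two aromatic carbons. The basic nitrogen, the saturated chain and the two aromatic rings of compound 2 are kept; only the ring around that nitrogen is opened into two ethyl groups.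

For the measured compounds named here, no measured pair shows what this exchange does here. With the rest of compound 2 unchanged, the expected outcome is a step in this assay that is small to moderate, toward a higher number if anything, and possibly within the scatter. Compound 3 is expected to give 0.4 nM, with a range of 0.08 nM to 2 nM, which corresponds to an estimated step of a 4.4-fold higher number from compound 2 to compound 3 (0.65 log units; beyond the scatter).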

Compound 3, inhibition constant: 1.4 nM
Compound 3: middle estimate off by 3.5-fold (0.54 log units), on the low side; the range from low to high includes it.
By their numbers in this assay, from the lowest: compound 2; then compound 3; then compound 1.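

In this assay, for the compounds shown here, diethylamino in place of 4-methylpiperidin-1-yl on a saturated chain carbon, five bonds along the chain from two aromatic carbons, gives a 16-fold higher number from compound 2 to compound 3 (1.19 log units; beyond the scatter), the first single-place step and a large one. This position is therefore sensitive to the amine it carries, even with the chain and the two aromatic rings unchanged, although compound 3 still reads 1.4 nM, so the ring-opened form keeps nanomolar affinity. No supporting data are available to explain why the two amines differ.

The change removes the ring and the methyl group together and alters the heavy-atom count, so this single step cannot apportion its size among those differences; unsubstituted piperidin-1-yl, pyrrolidin-1-yl or dimethylamino at the same place would help separate them. As far as these compounds go, it also remains open whether the same exchange gives a step of similar size on a shorter or longer chain, or with one of the two phenyl rings replaced by a pyridine ring.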